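A carboxy swap at the limit of the assay

The source may hold more compounds than are shown below. What is called first, only, known or untested is meant among the compounds shown, and "the series" means these compounds.

Compounds measured in a functional assay on RAW264.7 cells (Mus musculus) for inhibition, read by Griess assay, with stated times of 2 h and 18 h (a higher number here means a weaker inhibitor, a lower number a stronger inhibitor), are shown here, and each value is a limit of the assay and not a number.

- Compound 1 `CC1=C(CCc2ccoc2)[C@@]2(C)CCCC(C)(C)[C@@H]2[C@H](O)C1=O` gives > 50000 nM
- Compound 2 `C[C@@H]1[C@@H](O)C(=O)[C@H]2C(C)(C)CCC[C@]2(C)[C@@]1(O)CCc1ccoc1` gives > 50000 nM
- Compound 3 `COC(OC)[C@@]1(C)CCC[C@@]2(C)[C@H]1CC=C(C)[C@@H]2CC/C(C)=C/CO` gives > 50000 nM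

Compound 3 therefore has no number of its own in this assay, only the limit > 50000 nM that it reached. Within the data shown here, its two companions share that position (the limit of > 50000 nM in this assay, at which 3 of the 3 values shown sit), so no step between measured compounds is available to set a scale.

Compound 4 `CC1=CC[C@@H]2[C@](C)(CCC[C@]2(C)C(=O)O)[C@H]1CC/C(C)=C/CO` differs from compound 3 in one place (carboxy in place of dimethoxymethyl on a saturated ring carbon), with carboxy in place of dimethoxymethyl on a saturated ring carbon. With nothing yet measured under the limit, only a small shift towards stronger inhibition is expected in this assay, and the reading may well stay at the limit. The expected change is estimated as an at least 1.2-fold lower number from compound 3 to compound 4 (0.09 log units; that floor lies within the scatter), a modest one. The estimate for compound 4 is 40000 nM (expected range 15000 nM to 70000 nM).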

Compound 4, half-maximal inhibitory concentration: 41100 nM
Estimate against measurement, compound 4: 1.0-fold (0.01 log units) below; low and high end bracket the measured number.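

Compound 4 is the only one of the compounds shown with a number of its own in this assay, at 41100 nM. Carboxy in place of dimethoxymethyl on a saturated ring carbon gives an at least 1.2-fold lower number from compound 3 to compound 4 (0.08 log units; that floor lies within the scatter). That figure is a floor and not the full size of the step, because compound 3 has only a limit to start from: the limit of > 50000 nM in this assay, at which 3 of the 4 values shown sit.

The true size of the step therefore remains open, since the compounds shown give no number for compound 3. Also open, on these data alone, is whether a methyl ester, a primary amide or a hydroxymethyl group on the same saturated ring carbon would read like carboxy or stay at the limit of this assay.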